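Adding a Second Trifluoromethyl to the Hydrazone Ring

The source may report more compounds than this note shows. Statements on the series, on what has been measured and on what is new or still open speak of the compounds shown alone.

Measured so far:
compound 1, `CN(C(=O)NC(=O)c1ccc(F)c(F)c1)c1nc(C(F)(F)F)c(C(=O)N/N=C/c2cc(C(F)(F)F)cc(C(F)(F)F)c2)s1`: 3.51 ug/mL
compound 2, `CN(C(=O)NC(=O)c1ccc(C(F)(F)F)cc1)c1nc(C(F)(F)F)c(C(=O)N/N=C/c2cccc(C(F)(F)F)c2)s1`: 1.84 ug/mL

Compound 2 was tested in a functional assay on BCG823 cells (Homo sapiens) for inhibition, read by MTT assay, with a stated time of 72 h (a higher number here means a weaker inhibitor, a lower number a stronger inhibitor), and gave 1.84 ug/mL. Compound 1 gave 3.51 ug/mL in this assay, and the two values lie within the usual scatter of each other, so the data do not tell them apart.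

Compound 3, `CN(C(=O)NC(=O)c1ccc(C(F)(F)F)cc1)c1nc(C(F)(F)F)c(C(=O)N/N=C/c2cc(C(F)(F)F)cc(C(F)(F)F)c2)s1`, has not yet been measured. It differs from compound 2 in one place: trifluoromethyl in place of hydrogen on an aromatic carbon. Among the compounds with values here, no measured pair shows this single change on its own. Compound 1 carries the same two-trifluoromethyl ring as compound 3 but a different benzoyl part, so it cannot serve as a direct guide. A step in this assay no larger than the scatter is expected, with no clear direction; compound 3 is estimated at 2.4 ug/mL, in a range from 1 ug/mL to 5.8 ug/mL, which means an expected step of a 1.3-fold higher number from compound 2 to compound 3 (0.12 log units; within the scatter).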

Compound 3, half-maximal inhibitory concentration: 1.77 ug/mL
Beside the measured number, compound 3's estimate is 1.4-fold (0.13 log units) above it, within the range that was stated.
By their numbers in this assay, from the lowest: compounds 3, 2 and 1 (each within the scatter of the next).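

In this assay, trifluoromethyl in place of hydrogen on this aromatic carbon gives a 1.0-fold lower number from compound 2 to compound 3 (0.02 log units; within the scatter), so the first direct view of this change shows no effect that can be told from the scatter. Compound 3 also creates a matched pair for the benzoyl part: 4-(trifluoromethyl)phenyl in place of 3,4-difluorophenyl on a carbonyl carbon gives a 2.0-fold lower number from compound 1 to compound 3 (0.30 log units; within the scatter), and this step also lies within the scatter. No supporting measurement is available to explain either result.

The compounds shown carry only hydrogen or trifluoromethyl on this carbon, so what an amine or a carboxylic acid would do there remains open. Within the data shown here, the change is also seen in only one pair, so its size with the 3,4-difluorophenyl group in place remains unknown.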